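The source may report more compounds than this note shows. Statements on the series, on what has been measured and on what is new or still open speak of the compounds shown alone.

Measured so far:
Compound 1 `COc1ccc(/C=C2\CCC/C(=C\c3cccc(Cl)c3)C2=O)cc1OC`: 11900 nM
Compound 2 `COc1ccc(/C=C2\CCC/C(=C\c3ccccc3Br)C2=O)cc1OC`: 21800 nM
Compound 3 `COc1ccc(/C=C2\CCC/C(=C\c3ccc(Br)cc3)C2=O)cc1OC`: 13100 nM

These three compounds share one core and differ only in the halogen-bearing phenyl group. In an ADME assay on NHDF cells (Homo sapiens) for cytotoxicity, read by MTT assay, with a stated time of 72 h (a higher number here means a weaker inhibitor, a lower number a stronger inhibitor), compound 3 cannot be separated from the other two: there is a 1.1-fold higher number from compound 1 to compound 3 (0.04 log units; within the scatter), and there is a 1.7-fold lower number from compound 2 to compound 3 (0.22 log units; within the scatter).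

Compound 4 `COc1ccc(/C=C2\CCC/C(=C\c3ccc(OC)c(OC)c3)C2=O)cc1` is still unmeasured. Relative to compound 3, it has methoxy in place of bromo on an aromatic carbon, so 4-bromophenyl becomes 4-methoxyphenyl.

The measured steps that bear on this change are those made at the same group. Besides the two above, there is a 1.8-fold higher number from compound 1 to compound 2 (0.26 log units; within the scatter). All three are small, but they only exchange or move a halogen, and none brings in a methoxy group. The data therefore offer no direct test of this change and no argument for a direction. On this limited evidence, no step beyond the scatter is expected in this assay.

The expected change is a 1.1-fold higher number from compound 3 to compound 4 (0.03 log units; within the scatter).

The estimate for compound 4 is 14000 nM, with an expected range from 6000 nM to 30000 nM.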

Compound 4, half-maximal inhibitory concentration: 30900 nM
The estimate for compound 4 lay 2.2-fold (0.34 log units) below the measured number; the measured number lies above the stated range.
By their numbers in this assay, from the lowest: compounds 1, 3, 2 and 4 (each within the scatter of the next, the first and the last beyond it).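

In this assay this position now shows its first steps beyond the scatter: there is a 2.4-fold higher number from compound 3 to compound 4 (0.37 log units; beyond the scatter) when methoxy replaces bromo, and there is a 2.6-fold higher number from compound 1 to compound 4 (0.41 log units; beyond the scatter) when the 4-methoxyphenyl group replaces 3-chlorophenyl. So the group here can shift the number, which the halogen swaps alone did not show. Compound 2 goes against a clean split between halogens and methoxy, as there is a 1.4-fold higher number from compound 2 to compound 4 (0.15 log units; within the scatter) and the two cannot be told apart. Nothing available explains why the number rises with this change.

Methoxy is the only group here that is not a halogen, so this single example does not show a trend. From the compounds shown here alone, how an amine, a carboxylic acid or a longer chain such as ethoxy would behave at this position remains open.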